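Adding a Bromine to Compound 2

The source may hold more compounds than are shown below. What is called first, only, known or untested is meant among the compounds shown, and "the series" means these compounds.

Of the compounds shown here, two have so far been tested in a functional assay on the whole organism with Mus musculus as the target, with a stated time of 15 min; a lower number here means that less compound is needed, a higher number that more compound is needed for the effect. Compound 1 `Cc1sc2c(Cl)cccc2c1C1C=CN=CN1` gives 30 mg/kg, and compound 2 `CCc1ccc(C2C=CN=CN2)s1` gives 10 mg/kg. Compound 2 therefore shows the lower of the two numbers, and its gap to compound 1 lies beyond the usual scatter of such measurements.

Compound 3 `CCc1cc(Br)c(C2C=CN=CN2)s1` has not yet been measured in this assay. It differs from compound 2 in one place: bromo in place of hydrogen on an aromatic carbon. The bromine sits on the five-membered aromatic ring with one sulfur, two ring bonds from the ring sulfur and two ring bonds from the ring atom that bears an ethyl group.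

Within the data shown here, no measured pair shows what such a change does here, so the data give no direction for this step. The step of no change at the digits printed from compound 2 to compound 3 (within the scatter) is expected to stay within the scatter. Compound 3 is thus estimated at 10 mg/kg, with a likely range from 3 mg/kg to 30 mg/kg.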

Compound 3, minimum effective dose: 30 mg/kg
Compound 3: the middle estimate sits 3.0-fold (0.48 log units) below what was measured; the range from low to high includes it.
By their numbers in this assay, from the lowest: compound 2; then compounds 1 and 3 (each within the scatter of the next).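

Among these compounds, this is the first step that can be read from a pair differing in one place: in this assay, bromo in place of hydrogen gives a 3.0-fold higher number from compound 2 to compound 3 (0.48 log units; beyond the scatter) and so more compound is needed for the effect. Though modest, the step lies beyond the scatter, so what this aromatic carbon carries, next to the ring atom that bears a group of 6 heavy atoms, can change the dose required. Nothing in the available data accounts for this step.

A single change at a single place cannot show whether another group on this carbon, such as a fluorine atom, a methoxy group or an amine, would also raise the number. Going by these compounds, it also remains open whether bromo would give a step of similar size with a longer chain in place of the ethyl group.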